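This account rests on a few compounds, and the source may have more. Where it says the series, first, only, none or still open, it means among the compounds named here.

Working notes on the series.

Compound 2 `N#Cc1c(Nc2cccc(Cl)c2)nc(SCc2cn(Cc3ccccc3Cl)nn2)nc1-c1ccccc1` is the reference for the next step. In a functional assay on MCF7 cells (Homo sapiens) for inhibition, read by MTT assay, with a stated time of 72 h (a higher number here means a weaker inhibitor, a lower number a stronger inhibitor), compound 2 gives 12000 nM. The only other measured member, compound 1 `N#Cc1c(Nc2cccc(C(F)(F)F)c2)nc(SCc2cn(Cc3ccccc3Cl)nn2)nc1-c1ccccc1`, gives 12600 nM in this assay; the step of a 1.1-fold lower number from compound 1 to compound 2 (0.02 log units; within the scatter) lies within the scatter, so the two values cannot be told apart on the numbers shown, and compound 2 carries the lower of two values that are otherwise indistinguishable.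

Compound 3 `Cc1cccc(Nc2nc(SCc3cn(Cc4ccccc4Cl)nn3)nc(-c3ccccc3)c2C#N)c1` has not yet been measured. Its difference from compound 2 is methyl in place of chloro on an aromatic carbon, that is, the group sitting on the aromatic carbon of the six-membered carbon ring, meta to a large group, is exchanged once more.

Going by the values given here, the one step that bears on this exchange is the step from compound 1 to compound 2, which varied the same position and gave a 1.1-fold lower number from compound 1 to compound 2 (0.02 log units; within the scatter), a change within the scatter. On that basis a further exchange at this position is expected to move this assay by no more than the scatter, with no direction to assign. The expected step is therefore no change at the digits printed from compound 2 to compound 3 (within the scatter), and compound 3 is estimated at 12000 nM, with a range from 6000 nM to 25000 nM.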

Compound 3, half-maximal inhibitory concentration: 19600 nM
Compound 3: middle estimate off by 1.6-fold (0.21 log units), on the low side; the measured number falls inside the stated range.
By their numbers in this assay, from the lowest: compounds 2, 1 and 3 (each within the scatter of the next).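

Methyl is the first group at this place without a halogen, and in this assay it adds a third reading to the comparison: a 1.6-fold higher number from compound 2 to compound 3 (0.21 log units; within the scatter) and a 1.6-fold higher number from compound 1 to compound 3 (0.19 log units; within the scatter) both stay within the scatter. The earlier pair could speak only for chloro and trifluoromethyl, whereas the three compounds now show that 3-chlorophenyl, the trifluoromethyl counterpart and 3-methylphenyl on the shared core cannot be told apart on these numbers, so a halogen in this group is not needed for values of this size in this assay. No measurement shown here gives a reason for these values.

The compounds shown leave open whether a group of a different kind on this aromatic carbon, such as an amine, a carboxylic acid or a longer chain, would give a step beyond the scatter. From the compounds shown here alone, all three compounds also carry their group at the same place on the ring, so what the same groups would do elsewhere on that ring remains unknown.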